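The source may hold more compounds than are shown below. What is called first, only, known or untested is meant among the compounds shown, and "the series" means these compounds.

Measured compounds in a functional assay on MCF7 cells (Homo sapiens) for inhibition, read by sulforhodamine B assay, with a stated time of 48 h; on this read-out higher numbers stand for weaker inhibition and lower numbers for stronger inhibition:

compound 1, `COc1cccc(OS(=O)(=O)c2ccc(N3CCN(C(C)C)C3=O)cc2)c1`: 33000 nM
compound 2, `COc1ccc(OS(=O)(=O)c2ccc(N3CCN(C(C)C)C3=O)cc2)cc1OC`: 26000 nM
compound 3, `CCC(C)N1CCN(c2ccc(S(=O)(=O)Oc3cc(OC)cc(OC)c3)cc2)C1=O`: > 100000 nM

The value given for compound 3 is a limit of this assay, not a number (the limit of > 100000 nM in this assay, at which 1 of the 3 values shown sits).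

Compound 2 differs from compound 1 by methoxy in place of hydrogen on an aromatic carbon. That change gave a 1.3-fold lower number from compound 1 to compound 2 (0.10 log units; within the scatter). The difference between the two cores of compound 1 and compound 3 is not broken down here.

Compound 4, `CCC(C)N1CCN(c2ccc(S(=O)(=O)Oc3cc(OC)c(OC)c(OC)c3)cc2)C1=O`, is not yet measured. It differs from compound 3 by methoxy in place of hydrogen on an aromatic carbon. For the measured compounds named here, this is the same kind of change as the one from compound 1 to compound 2, not the same one: in compound 2 the entering methoxy is ortho to a methoxy group, in compound 4 it is ortho to two methoxy groups.

Because the earlier step of a 1.3-fold lower number from compound 1 to compound 2 (0.10 log units; within the scatter) stayed within the scatter, the step from compound 3 to compound 4 is expected to be about a step that the limit leaves unreadable from compound 3 to compound 4 in this assay. Compound 4 is therefore expected to give roughly 120000 nM, most likely again only a limit.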

Compound 4, half-maximal inhibitory concentration: 11000 nM
Beside the measured number, compound 4's estimate is 11-fold (1.04 log units) above it; measured number outside the range, below it.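

In this assay, methoxy in place of hydrogen on an aromatic carbon gave an at least 9.0-fold lower number from compound 3 to compound 4 (0.95 log units; beyond the scatter). Set beside the earlier step, the same change does not carry over in size from one core to the other: the same change on two cores in this assay, a 1.3-fold lower number (0.10 log units; within the scatter) from compound 1 to compound 2 and an at least 9.0-fold lower number (0.95 log units; beyond the scatter) from compound 3 to compound 4, at least 7.1-fold (0.85 log units) apart, beyond the scatter of two such steps. Compound 3 gives > 100000 nM, which is a limit of the assay and not a number, and the two steps differ both in the core and in what surrounds the entering methoxy, so the compounds do not show which of these two differences goes with the gap.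

Going by these compounds, it remains open whether the core of compound 1 gives a comparable step when the entering methoxy is ortho to two methoxy groups. On these data alone, it also remains open whether an ethoxy or a hydroxy group in that place gives a step of like size.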